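The compounds below may be only part of what the source reports. "The series", "measured", "known", "first", "only" and "open" are said of these compounds alone.

Notes on the series.

Within the data shown here, compound 1 `COc1cc(OC)c(-c2coc3cc(OCC=C(C)C)ccc3c2=O)cc1OC` gives 1090 nM in a functional assay on B16 cells (Mus musculus) for antiproliferative activity, read by MTT assay, with a stated time of 24 h (on this read-out lower numbers stand for stronger inhibition and higher numbers for weaker inhibition), the lowest of the three numbers measured so far. Compound 2 `COc1cc(OC)c(-c2coc3cc(OCc4ccccc4F)ccc3c2=O)cc1OC` gives 1610 nM in this assay, and compound 3 `COc1cc(OC)c(-c2coc3cc(OCc4ccccc4C(F)(F)F)ccc3c2=O)cc1OC` gives 8550 nM. The steps run a 1.5-fold higher number from compound 1 to compound 2 (0.17 log units; within the scatter), a 7.8-fold higher number from compound 1 to compound 3 (0.89 log units; beyond the scatter) and a 5.3-fold higher number from compound 2 to compound 3 (0.73 log units; beyond the scatter).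

Compound 4 `COc1cc(OC)c(-c2coc3cc(OCc4ccccc4C#N)ccc3c2=O)cc1OC` is unmeasured. Relative to compound 1 the change is 2-cyanophenyl in place of 2-methylprop-1-en-1-yl on a saturated chain carbon bound to an oxygen on an aromatic ring

Both measured steps from compound 1 replace the 2-methylprop-1-en-1-yl with a substituted phenyl and bear on this one: the step to compound 2 stays within the scatter, while the step to compound 3 is a modest loss. A 2-cyanophenyl is a third such phenyl, so compound 4 is expected to sit between those two outcomes, that is a small to modest rise in the number, plausibly at the edge of the scatter; the expected step is a 2.3-fold higher number from compound 1 to compound 4 (0.36 log units; beyond the scatter). On this basis compound 4 is estimated at 2500 nM in this assay, with a range from 1000 nM to 7000 nM.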

Compound 4, half-maximal inhibitory concentration: 2140 nM
Compound 4: the middle estimate sits 1.2-fold (0.07 log units) above what was measured, and the stated range covers the measured number.
By their numbers in this assay, from the lowest: compounds 1, 2 and 4 (each within the scatter of the next); then compound 3.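

In this assay the 2-cyanophenyl, like the 2-fluorophenyl, stays close to the 2-methylprop-1-en-1-yl on this saturated chain carbon, with a 2.0-fold higher number from compound 1 to compound 4 (0.29 log units; within the scatter) still inside the usual scatter. On the aromatic carbon, cyano in place of fluoro gives a 1.3-fold higher number from compound 2 to compound 4 (0.12 log units; within the scatter) and stays within the scatter, while cyano in place of trifluoromethyl gives a 4.0-fold lower number from compound 3 to compound 4 (0.60 log units; beyond the scatter) and lies beyond it, so among the three substituted phenyls shown, only the 2-(trifluoromethyl)phenyl of compound 3 stands apart. The data shown offer no explanation for this separation.

Still open, on these data alone, is whether the substituent on the phenyl matters at all, which an unsubstituted phenyl would test, and how a carboxylic acid or an amine on that aromatic carbon would read. As far as these compounds go, a longer chain in place of the 2-methylprop-1-en-1-yl is also open, as is whether any group here can reach a number clearly lower than that of compound 1.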